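Cytotoxicity notes: replacing the furan-2-yl group

The source may hold more compounds than are shown below. What is called first, only, known or untested is meant among the compounds shown, and "the series" means these compounds.

Measured compounds:
- compound 1, `CC1(c2ccc(-c3ccco3)cc2)CC(S(=O)(=O)c2ccc(F)cc2)=C(c2ccc(/C(N)=N\O)cc2)O1`: 4560 nM in an ADME assay on J774.A1 cells (Mus musculus) for cytotoxicity, read by MTT assay, with a stated time of 72 h; a lower number here means that less compound is tolerated, a higher number that more compound is tolerated
- compound 2, `Cc1ccc(-c2ccc(C3(C)CC(S(=O)(=O)c4ccc(F)cc4)=C(c4ccc(/C(N)=N\O)cc4)O3)cc2)cc1`: 7910 nM
- compound 3, `CC1(c2ccc(-c3cccc(/C(N)=N\O)c3)cc2)CC(S(=O)(=O)c2ccc(F)cc2)=C(c2ccc(/C(N)=N\O)cc2)O1`: 11000 nM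

Compound 1 holds the lowest number of the three; compound 2 sits within the scatter of it, while compound 3 is beyond it a 2.4-fold higher number from compound 1 to compound 3 (0.38 log units; beyond the scatter). Compound 4, `CC1(c2ccc(Br)cc2)CC(S(=O)(=O)c2ccc(F)cc2)=C(c2ccc(/C(N)=N\O)cc2)O1`, differs from compound 1 in one place: bromo in place of furan-2-yl on an aromatic carbon. Within the data shown here, the two measured steps from compound 1 both exchange furan-2-yl for a larger ring group, giving a 1.7-fold higher number from compound 1 to compound 2 (0.24 log units; within the scatter) and a 2.4-fold higher number from compound 1 to compound 3 (0.38 log units; beyond the scatter); neither puts a single atom in its place, so no measured step bears on this change directly. With nothing pointing either way, compound 4 is expected to stay near compound 1, a step of a 1.0-fold lower number from compound 1 to compound 4 (0.01 log units; within the scatter) in this assay not beyond the scatter. Compound 4 is therefore estimated at 4500 nM, within 2200 nM to 9500 nM.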

Compound 4, half-maximal cytotoxic concentration: 10500 nM
Beside the measured number, compound 4's estimate is 2.3-fold (0.37 log units) below it; the measured number lies above the stated range.
By their numbers in this assay, from the lowest: compounds 1, 2, 4 and 3 (each within the scatter of the next, the first and the last beyond it).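

At this position a single atom is enough to move the number in this assay: the change from furan-2-yl to bromo gives a 2.3-fold higher number from compound 1 to compound 4 (0.36 log units; beyond the scatter), so a second ring is not needed for a step beyond the scatter. Bromo set against the larger groups gives a 1.3-fold higher number from compound 2 to compound 4 (0.12 log units; within the scatter) and a 1.0-fold lower number from compound 3 to compound 4 (0.02 log units; within the scatter), so heavy-atom count does not separate these compounds. No available data explain the step from furan-2-yl to bromo.

On these data alone, whether furan-2-yl alone sits apart remains open, as compound 2 stays within the scatter of compound 1. An amine or a carboxylic acid at this position would test how general the higher numbers are.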